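The source may hold more compounds than are shown below. What is called first, only, known or untested is meant among the compounds shown, and "the series" means these compounds.

Measured compounds:
- compound 1, `O=C([C@@H]1C[C@H](NCc2ccccc2)CN1)N1CCSC1`: 171 nM
- compound 2, `O=C(Nc1ccccc1)N[C@@H]1CN[C@H](C(=O)N2CCSC2)C1`: 151 nM
- compound 3, `CC(C)N(Cc1ccc(C#N)cc1)[C@@H]1CN[C@H](C(=O)N2CCSC2)C1`: 12.5 nM

All three were tested in an assay on a cell-free system (plasma) for inhibition of Dipeptidyl peptidase 4 (Rattus norvegicus), read by fluorescence; a lower number here means a stronger inhibitor, a higher number a weaker inhibitor. Among them compound 3 gives the lowest number, and its gap to compound 2 and to compound 1 lies beyond the usual scatter, so compound 3 is the strongest inhibitor of the three. Compound 1 and compound 2 give numbers close to each other, and nothing more can be said of that pair.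

The next compound, compound 4, `N#Cc1ccc(CN(CC(=O)O)[C@@H]2CN[C@H](C(=O)N3CCSC3)C2)cc1`, keeps the whole of compound 3 except for one group: carboxymethyl in place of isopropyl on an amine nitrogen. Among the compounds with values here, no pair of measured compounds differs in this way, so there is no measured step that shows how this assay responds to such a change; the three measured compounds only show that the substituents on this nitrogen matter a great deal.

The expectation for compound 4 is therefore a cautious one: a modest step upward, from compound 3 to compound 4 of a 2.8-fold higher number from compound 3 to compound 4 (0.45 log units; beyond the scatter), which may or may not go beyond the scatter. The estimate for compound 4 is 35 nM, with a range from 8 nM to 150 nM.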

Compound 4, half-maximal inhibitory concentration: 16.3 nM
Beside the measured number, compound 4's estimate is 2.1-fold (0.33 log units) above it; low and high end bracket the measured number.
By their numbers in this assay, from the lowest: compounds 3 and 4 (each within the scatter of the next); then compounds 2 and 1 (each within the scatter of the next).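

In this assay, placing carboxymethyl instead of isopropyl on this amine nitrogen gives a 1.3-fold higher number from compound 3 to compound 4 (0.12 log units; within the scatter), so the measurement does not separate the two compounds. Within the data shown here, this is the first measured single change at this position, and it shows that inhibition holds when a small hydrocarbon group gives way to one with two oxygen atoms, a hydrogen-bond donor and a hydrogen-bond acceptor. At least for this pair, the nitrogen substituent can therefore differ considerably in make-up with no visible change in the reading, although nothing available explains why the two groups read alike.

The compounds shown leave open whether this tolerance extends to other groups at the same nitrogen, such as a primary amine on a short chain, a methyl ester, or a longer chain ending in a carboxylic acid. As far as these compounds go, they also do not show what a bare hydrogen on this nitrogen would give, so it remains unknown whether isopropyl and carboxymethyl contribute to inhibition at all, or whether the same swap would read alike with a different group in place of the other substituent on the nitrogen.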